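The source may hold more compounds than are shown below. What is called first, only, known or untested is meant among the compounds shown, and "the series" means these compounds.

The measured compounds so far:
compound 1, `COc1cc(C(C)=O)ccc1OCCCCN1CCC(C(c2ccc(F)cc2)c2ccc(F)cc2)CC1`, giving 2.51 nM
compound 2, `Fc1ccc(OCCCN2CCC(C(c3ccc(F)cc3)c3ccc(F)cc3)CC2)cc1`, giving 1.26 nM
compound 3, `Fc1ccc(C(c2ccc(F)cc2)C2CCN(CCCOc3ccc(Br)cc3)CC2)cc1`, giving 1.59 nM

All three were tested in a functional assay (aorta) with Oryctolagus cuniculus as the target; a lower number here means tighter binding, a higher number weaker binding. Compound 3 stands second highest of the three numbers, and both neighbours lie within the scatter of it, so no order among them can be claimed. Compound 4, `Fc1ccc(C(c2ccc(F)cc2)C2CCN(CCCCc3ccccc3)CC2)cc1`, is not yet measured; it differs from compound 3 by benzyl in place of 4-bromophenoxy on a saturated chain carbon, three bonds along the chain from an amine nitrogen in a ring. Going by the values given here, the only measured single step, a 1.3-fold higher number from compound 2 to compound 3 (0.10 log units; within the scatter), replaces one halogen with another on an aromatic carbon and so says little about dropping the oxygen and the bromine together. Among the compounds with values here, with no close precedent, only a modest step is expected, a 2.0-fold higher number from compound 3 to compound 4 (0.30 log units; within the scatter), leaning toward a higher number. Compound 4 is therefore estimated at 3.2 nM, within a range from 1 nM to 10 nM.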

Compound 4, dissociation constant: 2.51 nM
Compound 4: middle estimate off by 1.3-fold (0.11 log units), on the high side, and the stated range covers the measured number.
By their numbers in this assay, from the lowest: compounds 2, 3, 1 and 4 (each within the scatter of the next).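

In this assay, the chain keeps its place in the range without the oxygen or the halogen: benzyl in place of the halogenated phenoxy groups gives a 1.6-fold higher number from compound 3 to compound 4 (0.20 log units; within the scatter) and a 2.0-fold higher number from compound 2 to compound 4 (0.30 log units; within the scatter). Phenyl in place of 4-acetyl-2-methoxyphenoxy, a larger change to the ring, gives no change at the digits printed from compound 1 to compound 4 (within the scatter), so all three new steps stay within the scatter. No measurement is available to explain this tolerance. From the compounds shown here alone, whether an amine or a carboxylic acid on the ring, or a longer chain, would move the number beyond the scatter remains open.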